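This account rests on a few compounds, and the source may have more. Where it says the series, first, only, none or still open, it means among the compounds named here.

Measured compounds:
compound 1 `CC1CCN(C2CCN(S(=O)(=O)c3ccc(C(C)(C)C)cc3)CC2)CC1` — > 5000 nM
compound 2 `COc1cc(C)ccc1S(=O)(=O)N1CCC(N2CCC(C)CC2)CC1` — > 5000 nM
compound 3 `Cc1cc(C)c(S(=O)(=O)c2ccc(N3CCC(C)CC3)cc2)c(C)c1` — > 5000 nM

In a functional assay on DLD-1 cells (Homo sapiens) for antiproliferative activity, read by CellTiter-Glo, with a stated time of 72 h (a higher number here means a weaker inhibitor, a lower number a stronger inhibitor), compound 1 gives > 5000 nM, which is a limit of the assay and not a number. Compound 2 likewise gives > 5000 nM, a limit. Compound 3 gives > 5000 nM, again a limit. All three values sit at the limit of > 5000 nM in this assay, at which 3 of the 3 values shown sit, so compound 1 stands at the limit together with the other two, and no order of potency among them can be drawn from these numbers.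

Compound 4 `CC1CCN(C2CCN(S(=O)(=O)c3ccc(C#N)cc3)CC2)CC1` differs from compound 1 in one place: cyano in place of tert-butyl on an aromatic carbon.

Among the measured compounds shown here, no step between measured compounds is available, so the effect of this change in this assay cannot be read from the data. The step that the limit leaves unreadable from compound 1 to compound 4 is expected to be none beyond the scatter. Compound 4 is therefore estimated at 9000 nM, with a range from 3000 nM to 30000 nM, and it is expected that the assay will most likely again report only a limit for compound 4.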

Compound 4, half-maximal inhibitory concentration: 2800 nM
Compound 4: middle estimate off by 3.2-fold (0.51 log units), on the high side, and the stated range ends above it.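

In this assay compound 4 gives 2800 nM, the only value among the compounds shown that is a number and not a limit. Compound 1 gives > 5000 nM, which is a limit. Cyano in place of tert-butyl on this aromatic carbon gives an at least 1.7-fold lower number from compound 1 to compound 4 (0.25 log units; that floor lies within the scatter), so this position now has one readable value, but the change cannot yet be said to go beyond the scatter, and its true size stays unknown because one end of the step is a limit: the limit of > 5000 nM in this assay, at which 3 of the 4 values shown sit.

One pair cannot tell whether the lower number goes with the arrival of cyano or the departure of tert-butyl. Going by these compounds, what an amine, a carboxylic acid or a primary amide would give at this position remains open.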